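The source may report more compounds than this note shows. Statements on the series, on what has been measured and on what is new or still open speak of the compounds shown alone.

Of the compounds shown here, two from this series have been measured in a functional assay (Pituitary gland cell) with Rattus norvegicus as the target; a lower number here means that less compound is needed, a higher number that more compound is needed for the effect. Compound 1, `C[C@@H](O)CNC(C)(C)CC(=O)N[C@@H]1CCc2ccccc2N(Cc2ccc(-c3ccccc3C(N)=O)cc2)C1=O`, gives 4 nM in this assay. Compound 2, `CC(C)(CC(=O)N[C@@H]1CCc2ccccc2N(Cc2ccc(-c3ccccc3-c3nn[nH]n3)cc2)C1=O)NC[C@H](O)CO`, gives 10 nM in this assay, the higher of the two numbers; compound 1 is the nearest point, and compound 1 and compound 2 differ in two places at once, so their values speak only for the pair as a whole and not for either change alone.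

Compound 3, `CC(C)(CC(=O)N[C@@H]1CCc2ccccc2N(Cc2ccc(-c3ccccc3C(N)=O)cc2)C1=O)NC[C@H](O)CO`, is the next compound to be measured. It differs from compound 2 in one place: carbamoyl in place of 2H-tetrazol-5-yl on an aromatic carbon. The rest of compound 3, including the three-carbon chain bearing two hydroxyl groups on the amine, is kept from compound 2.

Compound 3 carries the same carbamoylphenyl end as compound 1, which gives 4 nM in this assay. The step of a 2.0-fold lower number from compound 2 to compound 3 (0.30 log units; within the scatter) is therefore expected to be a modest move to a lower number, at or just beyond the edge of the usual scatter. For compound 3 the estimated value in this assay is 5 nM, with a range of 2 nM to 15 nM.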

Compound 3, concentration for half-maximal effect: 3 nM
Compound 3: middle estimate off by 1.7-fold (0.22 log units), on the high side; the range from low to high includes it.
By their numbers in this assay, from the lowest: compounds 3 and 1 (each within the scatter of the next); then compound 2.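

With the three-carbon chain bearing two hydroxyl groups held constant, the change on the aromatic carbon ortho to a large group can now be read alone in this assay, where carbamoyl in place of 2H-tetrazol-5-yl gives a 3.3-fold lower number from compound 2 to compound 3 (0.52 log units; beyond the scatter) and so places the 2-carbamoylphenyl end on the side of the lower number, a separation that the earlier pair, differing in two places at once, could not provide. Within the data shown here, the chain can also be read alone for the first time, and hydroxy in place of hydrogen on the saturated chain carbon gives a 1.3-fold lower number from compound 1 to compound 3 (0.12 log units; within the scatter) in this assay, so this change on the amine chain leaves the two compounds indistinguishable in this measurement. Nothing available accounts for the size of either step.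

Among these compounds, only two groups are compared at this aromatic carbon, so it remains open whether a carboxylic acid, a nitrile or a methyl ester there would give a number closer to that of the carbamoyl compounds or to that of the tetrazole compound. Going by these compounds, it also remains open whether a longer chain on the amine, or a bare primary amine, would stay as close to compound 3 as the shorter hydroxylated chain of compound 1 does.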